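A few compounds are considered here, and "the series" means these few. Any claim that something is new, unique, unknown or untested is made for them only; others in the source may bear on it.

Going by the values given here, in an ADME assay on MT4 cells (Homo sapiens) for cytotoxicity, read by MTT assay (on this read-out lower numbers stand for higher toxicity in this test and higher numbers for lower toxicity in this test), compound 3 `O=C1c2ccccc2C(=O)N1CCOC(=S)N(C(=O)c1cc(F)ccc1F)c1ccc(Cl)cc1` gives 54000 nM, the only reading here that is a number. For compound 1 `CCCCCOc1ccc(C(=O)N(C(=S)OCCN2C(=O)c3ccccc3C2=O)c2ccc(F)cc2)cc1` the result of > 100000 nM is a limit of the test, not a number. For compound 2 `Cc1ccc(N(C(=O)c2ccccc2C)C(=S)OCCN2C(=O)c3ccccc3C2=O)cc1` the result of > 100000 nM is likewise a limit. Because the limit of > 100000 nM in this assay, at which 2 of the 3 values shown sit, marks where those two readings sit, the gap from compound 3 to them cannot be sized. Compound 4 `Cc1cc(C(=O)N(C(=S)OCCN2C(=O)c3ccccc3C2=O)c2ccc(Cl)cc2)c(C)o1` differs from compound 3 by 2,5-dimethylfuran-3-yl in place of 2,5-difluorophenyl on a carbonyl carbon. Among the compounds with values here, no measured pair shows this exchange, so its effect is unknown; the step from compound 3 to compound 4 is expected to be a 1.3-fold higher number from compound 3 to compound 4 (0.11 log units; within the scatter), within the usual scatter or slightly toward lower toxicity. Compound 4 is therefore estimated at 70000 nM, with a likely range from 25000 nM to 200000 nM.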

Compound 4, half-maximal cytotoxic concentration: 40000 nM
Beside the measured number, compound 4's estimate is 1.8-fold (0.24 log units) above it; the range from low to high includes it.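

In this assay, going by these compounds alone, this is the first measured exchange on a carbonyl carbon whose other neighbour is an amide-type nitrogen: 2,5-dimethylfuran-3-yl in place of 2,5-difluorophenyl gives a 1.4-fold lower number from compound 3 to compound 4 (0.13 log units; within the scatter). For this one pair, then, a five-membered aromatic ring with a hetero atom and a six-membered carbon-only ring read alike at this place. Nothing measured here gives a reason for that.

Going by these compounds, how a ring carrying an amine or a carboxylic acid would read on this carbonyl carbon stays open. So does whether the exchange reads the same when the rest of the molecule differs.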